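The source may hold more compounds than are shown below. What is called first, only, known or untested is meant among the compounds shown, and "the series" means these compounds.

Working notes on the series in a functional assay on A549 cells (Homo sapiens) for cytotoxicity, read by MTT assay, with a stated time of 48 h; a higher number here means a weaker inhibitor, a lower number a stronger inhibitor. Compound 1, `CCN(CC)c1ccc2cc(C(=O)c3ccc(N4CCN(C(=O)CN5CCN(C(=O)CCl)CC5)CC4)cc3)oc2c1`, carries a (chloromethyl)carbonyl on the distal ring amine; in this assay compound 1 gives 3060 nM. Compound 2, `CCN(CC)c1ccc2cc(C(=O)c3ccc(N4CCN(C(=O)CN5CCN(S(=O)(=O)c6ccc(C#N)cc6)CC5)CC4)cc3)oc2c1`, carries (4-cyanophenyl)sulfonyl in its place. For compound 2 this assay reports only a limit, > 40000 nM, not a number. Among the measured compounds shown here, the single measured step is an at least 13-fold higher number from compound 1 to compound 2 (1.11 log units; beyond the scatter); it is bounded from one side only because of the limit of > 40000 nM in this assay, at which 1 of the 2 values shown sits, so compound 2 stands at the weak end of what this assay resolves. Compound 3, `CCN(CC)c1ccc2cc(C(=O)c3ccc(N4CCN(C(=O)CN5CCN(S(=O)(=O)c6ccc(F)cc6)CC5)CC4)cc3)oc2c1`, differs from compound 2 in one place: fluoro in place of cyano on an aromatic carbon. For the measured compounds named here, no measured step bears directly on a change of this kind; the only measured step concerns the exchange of the whole group on the ring amine, and that step was large. With compound 2 sitting at the limit, no direction can be read from the data for this swap, and the expectation is that compound 3 remains near the same limit. The expected step is a step that the limit leaves unreadable from compound 2 to compound 3. Compound 3 is therefore estimated at 45000 nM, with a range of 10000 nM to 200000 nM, and a fair chance that this assay again returns only a limit.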

Compound 3, half-maximal inhibitory concentration: 33200 nM
Estimate against measurement, compound 3: 1.4-fold (0.13 log units) above; the range from low to high includes it.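

Compound 3 gives the sulfonyl side of the series a real number in this assay, and the exchange on the ring amine reads as an 11-fold higher number from compound 1 to compound 3 (1.04 log units; beyond the scatter) in this case too, so the large rise in the number on leaving (chloromethyl)carbonyl is seen with (4-fluorophenyl)sulfonyl as well as with (4-cyanophenyl)sulfonyl. Compound 2 at > 40000 nM stands at a limit and not at a number. As far as these compounds go, on the aromatic carbon para to a large group, fluoro in place of cyano gives an at least 1.2-fold lower number from compound 2 to compound 3 (0.08 log units; that floor lies within the scatter) and so shows no change beyond the scatter, though the step stays open on one side because of the limit: the limit of > 40000 nM in this assay, at which 1 of the 3 values shown sits.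

Still open, from the compounds shown here alone, is how an amine or a carboxylic acid in place of fluoro on this ring would read, and whether any arylsulfonyl group on the ring amine comes near compound 1. Equally open, going by these compounds, is how an acetyl group on that ring amine, with the chlorine gone, would compare with compound 1 in this assay on the same shared core.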